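Fluorine on the Phenyl Ring: An Untested Pairing

This account rests on a few compounds, and the source may have more. Where it says the series, first, only, none or still open, it means among the compounds named here.

Measured in a functional assay on A549 cells (Homo sapiens) for cytotoxicity, read by MTT assay, with a stated time of 72 h; a higher number here means a weaker inhibitor, a lower number a stronger inhibitor:
compound 1 `COc1cc2c(Oc3ccc(NC(=O)c4cc(-c5ccccc5)ccn4)cc3F)ccnc2cc1OCCCN1CCN(C)CC1`: 340 nM
compound 2 `COc1cc2c(Oc3ccc(NC(=O)c4cc(-c5ccc(F)cc5)ccn4)cc3F)ccnc2cc1OCCCN1CCN(C)CC1`: "not determined" (no result reported)
compound 3 `COc1cc2c(Oc3ccc(NC(=O)c4cc(-c5ccccc5)ccn4)cc3F)ccnc2cc1OCCCN1CCCC1`: 1580 nM

Among the compounds with values here, compound 3 holds the highest of the two numbers in this assay; its nearest neighbour is compound 1, and the only measured step, a 4.6-fold higher number from compound 1 to compound 3 (0.67 log units; beyond the scatter), is the exchange of the chain-end amine. Compound 2 carries no number in this assay, so the fluorine question is open on the measured side.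

Compound 4 `COc1cc2c(Oc3ccc(NC(=O)c4cc(-c5ccc(F)cc5)ccn4)cc3F)ccnc2cc1OCCCN1CCCC1` differs from compound 3 by fluoro in place of hydrogen on an aromatic carbon. Within the data shown here, no measured step covers this change: compound 2 would have supplied it against compound 1, but its result is absent. With nothing to lean on, the expectation for compound 4 is a step from compound 3 of no size beyond the scatter, a 1.1-fold lower number from compound 3 to compound 4 (0.02 log units; within the scatter), and compound 4 is estimated at 1500 nM in this assay, within a range from 600 nM to 4000 nM.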

Compound 4, half-maximal inhibitory concentration: 1800 nM
The estimate for compound 4 lay 1.2-fold (0.08 log units) below the measured number; the measured number falls inside the stated range.
By their numbers in this assay, from the lowest: compound 1; then compounds 3 and 4 (each within the scatter of the next).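

In this assay, the change from phenyl to 4-fluorophenyl now has a measured step, a 1.1-fold higher number from compound 3 to compound 4 (0.06 log units; within the scatter). With pyrrolidin-1-yl at the chain end, fluoro in place of hydrogen on this aromatic carbon, para to a large group, therefore stays within the scatter, unlike the earlier exchange of the chain-end amine, which went beyond it. No measurement shown here speaks to the reason for this result.

On these data alone, the step from compound 1 to compound 2 cannot be read, so it remains open whether fluoro behaves the same way with 4-methylpiperazin-1-yl at the chain end. Also open, as far as these compounds go, is how chloro, methoxy or trifluoromethyl would stand at this place on the phenyl ring in this assay, or how morpholine would stand at the chain end.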